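Methoxybenzyl extension of a dimethylaminochalcone amine-oxidase inhibitor

The source may hold more compounds than are shown below. What is called first, only, known or untested is meant among the compounds shown, and "the series" means these compounds.

Measured compounds:
compound 1 `CN(C)c1ccc(/C=C/C(=O)c2ccc(N(C)C)cc2O)cc1` — 47900 nM
compound 2 `CCN(CCCCCCOc1ccc(C(=O)/C=C/c2ccc(N(C)C)cc2)c(O)c1)Cc1ccccc1` — 31600 nM
compound 3 `COc1ccc(C(=O)/C=C/c2ccc(N(C)C)cc2)c(O)c1` — 7620 nM

In an assay on isolated protein for inhibition of Amine oxidase [flavin-containing] A (Homo sapiens) (a higher number here means a weaker inhibitor, a lower number a stronger inhibitor), compound 2 sits second highest of the three numbers; compound 1 is within the scatter of it, while compound 3 lies beyond the scatter on the lower side. Going by the values given here, the one single-change step available, a 6.3-fold lower number from compound 1 to compound 3 (0.80 log units; beyond the scatter), concerns the other end of the shared core and does not involve the benzyl(ethyl)amino chain. Compound 4 `CCN(CCCCCCOc1ccc(C(=O)/C=C/c2ccc(N(C)C)cc2)c(O)c1)Cc1ccccc1OC` differs from compound 2 by methoxy in place of hydrogen on an aromatic carbon. Among the compounds with values here, no measured step bears on this change, so the expected shift is a 1.1-fold lower number from compound 2 to compound 4 (0.05 log units; within the scatter), nothing beyond the scatter. Compound 4 is therefore estimated at 28000 nM, with a range of 10000 nM to 80000 nM.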

Compound 4, half-maximal inhibitory concentration: 54300 nM
Beside the measured number, compound 4's estimate is 1.9-fold (0.29 log units) below it; low and high end bracket the measured number.
By their numbers in this assay, from the lowest: compound 3; then compounds 2, 1 and 4 (each within the scatter of the next).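

In this assay the change from benzyl to 2-methoxybenzyl gives a 1.7-fold higher number from compound 2 to compound 4 (0.24 log units; within the scatter) and so shows no readable effect of the added group on this aromatic carbon, ortho to a large group. Going by these compounds alone, this is the first step read at the benzyl(ethyl)amino end of the chain, as the earlier step concerned the other end of the shared core. No measured evidence bears on this result.

As far as these compounds go, whether hydroxyl or chlorine on this same carbon would give a step beyond the scatter remains open. So does the effect of a shorter chain carrying the benzyl(ethyl)amino group.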